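Swapping One Side Group on a Weakly Active Core

A few compounds are considered here, and "the series" means these few. Any claim that something is new, unique, unknown or untested is made for them only; others in the source may bear on it.

Compound 1 `COc1cccc(-c2cc(C(=O)Nc3cc4ccc(Oc5ccc(C(C)(C)C)cc5)c(C)c4oc3=O)ccc2OC)c1` is the starting point. In a functional assay on MCF7 cells (Homo sapiens) for antiproliferative activity (a higher number here means a weaker inhibitor, a lower number a stronger inhibitor), compound 1 reaches only a limit, > 100000 nM, and no number is known for it (the limit of > 100000 nM in this assay, at which 1 of the 2 values shown sits). Going by the values given here, the only other measured member of the series, compound 2 `CC(C)=CCc1cc(C(=O)Nc2cc3ccc(Cc4ccc(O)cc4)c(C)c3oc2=O)ccc1O`, gives 32100 nM in this assay. Compound 3 `COc1ccc(Cc2ccc3cc(NC(=O)c4ccc(OC)c(-c5cccc(OC)c5)c4)c(=O)oc3c2C)cc1` differs from compound 1 by 4-methoxybenzyl in place of 4-(tert-butyl)phenoxy on an aromatic carbon. Among the compounds with values here, no pair of measured compounds shows this kind of change, so the step of an at least 1.6-fold lower number from compound 1 to compound 3 (0.22 log units; that floor lies within the scatter) is expected to be modest and toward a somewhat stronger inhibitor. Compound 3 is therefore estimated at 60000 nM, with a likely range from 15000 nM to 150000 nM.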

Compound 3, half-maximal inhibitory concentration: > 100000 nM
Compound 3 was reported as a limit (the forecaster's own chance of this, stated with the estimate: 45%); middle value at least 1.6-fold (0.22 log units) from the limit.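

In this assay, going by these compounds alone, compound 1 and compound 3 each give only a limit, not a number, so no step between them can be read. On these data alone, whether 4-methoxybenzyl or 4-(tert-butyl)phenoxy gives the stronger inhibitor remains open.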